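The source may hold more compounds than are shown below. What is called first, only, known or untested is meant among the compounds shown, and "the series" means these compounds.

Measured so far:
Compound 1 `COc1ccc2nc(-c3n[nH]cc3/C=C/c3cccnc3)[nH]c2c1`: 2500 nM
Compound 2 `COC(=O)c1cncc(/C=C/c2c[nH]nc2-c2nc3ccc(OC)cc3[nH]2)c1`: 3100 nM

In a functional assay on A-375 cells (Homo sapiens) for antiproliferative activity (on this read-out higher numbers stand for weaker inhibition and lower numbers for stronger inhibition), compound 1 stands lowest of the two numbers shown, but the nearest, compound 2, sits at 3100 nM, and the step of a 1.2-fold higher number from compound 1 to compound 2 (0.09 log units; within the scatter) lies within the scatter, so the two cannot be ordered. Compound 3 `CN1CCN(c2ccc3nc(-c4n[nH]cc4/C=C/c4cccnc4)[nH]c3c2)CC1` has not yet been measured. It differs from compound 1 by 4-methylpiperazin-1-yl in place of methoxy on an aromatic carbon. Among the measured compounds shown here, the one measured step, from compound 1 to compound 2, concerns a different carbon and a different group, so it does not bear on this change; no measured pair shows what exchanging the methoxy for a 4-methylpiperazin-1-yl does. Without such a step, the expectation for compound 3 rests on compound 1 alone and is wide. The number expected for compound 3 is 2500 nM, within 700 nM to 9000 nM, meaning an expected step of no change at the digits printed from compound 1 to compound 3 (within the scatter), with no direction expected beyond the scatter.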

Compound 3, half-maximal inhibitory concentration: 860 nM
Beside the measured number, compound 3's estimate is 2.9-fold (0.46 log units) above it; the measured number falls inside the stated range.
By their numbers in this assay, from the lowest: compound 3; then compounds 1 and 2 (each within the scatter of the next).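

In this assay, among the compounds shown here, the step of a 2.9-fold lower number from compound 1 to compound 3 (0.46 log units; beyond the scatter) is the first in this set to lie beyond the scatter, whereas the methoxycarbonyl change seen earlier did not. It shows that this aromatic carbon, on the six-membered ring of carbon only within the fused system, accepts 4-methylpiperazin-1-yl with its non-aromatic ring in place of methoxy, and that the number falls modestly rather than rises. No measurement at hand accounts for this step.

The compounds shown leave open whether a smaller amine such as dimethylamino, a morpholine ring or a piperazine lacking the methyl would give a similar number at this carbon. They also leave open how 4-methylpiperazin-1-yl would behave alongside the methoxycarbonyl group of compound 2.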